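The source may report more compounds than this note shows. Statements on the series, on what has been measured and on what is new or still open speak of the compounds shown alone.

Compound 1, `COc1ccc(-c2ccc(-c3ccc(C(=N)N)cc3)s2)cc1`: 184 nM
Compound 2, `N=C(N)c1ccc(-c2ccc(-c3cc(Cl)cc(Cl)c3)s2)cc1`: 1310 nM
Compound 3, `COc1cc(OC)cc(-c2ccc(-c3ccc(C(=N)N)cc3)s2)c1`: 1870 nM

All three were tested in a functional assay on 786-0 cells (Homo sapiens) for inhibition, read by sulforhodamine B assay, with a stated time of 48 h; on this read-out lower numbers stand for stronger inhibition of growth and higher numbers for weaker inhibition of growth. Compound 1 gives the lowest number of the three, and both compound 2 and compound 3 sit above it by more than the usual scatter. Compound 4, `N=C(N)c1ccc(-c2ccc(-c3ccc(Cl)cc3)s2)cc1`, has not yet been measured. It differs from compound 1 in one place: chloro in place of methoxy on an aromatic carbon. Going by the values given here, no pair of measured compounds shows this exact change, so the three numbers alone guide the expectation. The step is expected to be small, likely within the scatter, with at most a slight weakening: a 1.6-fold higher number from compound 1 to compound 4 (0.21 log units; within the scatter). Compound 4 is therefore estimated at 300 nM, with a likely range from 100 nM to 900 nM.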

Compound 4, concentration for 50% growth inhibition: 178 nM
Compound 4: middle estimate off by 1.7-fold (0.23 log units), on the high side, and the stated range covers the measured number.
By their numbers in this assay, from the lowest: compounds 4 and 1 (each within the scatter of the next); then compounds 2 and 3 (each within the scatter of the next).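

At this position, para to a large group, the change of methoxy to chloro gives a 1.0-fold lower number from compound 1 to compound 4 (0.01 log units; within the scatter) in this assay. Going by these compounds alone, the earlier compounds offered no comparison that differed in one place, so this is the first direct reading: methoxy can leave and chloro can enter with no difference beyond the scatter. Nothing available explains why these two groups give such similar numbers. On these data alone, whether an amine, a carboxylic acid or a longer chain would give a similar number here remains open. So does whether this match would hold on a different core.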